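The source may hold more compounds than are shown below. What is called first, only, known or untested is meant among the compounds shown, and "the series" means these compounds.

In a functional assay on HL-60 cells (Homo sapiens) for antiproliferative activity, read by MTT assay, with a stated time of 72 h (on this read-out higher numbers stand for weaker inhibition of growth and lower numbers for stronger inhibition of growth), compound 1 `CCOC(=O)N1CCN(/[N+]([O-])=N/Oc2cc(O/N=[N+](\[O-])N(C)C)c([N+](=O)[O-])cc2[N+](=O)[O-])CC1` gives 2000 nM, compound 2 `CCCOC(=O)N1CCN(/[N+]([O-])=N/Oc2cc(O/N=[N+](\[O-])N(C)C)c([N+](=O)[O-])cc2[N+](=O)[O-])CC1` gives 3900 nM, and compound 3 `CN(C)/[N+]([O-])=N/Oc1cc(O/N=[N+](\[O-])N2CCN(c3ncccn3)CC2)c([N+](=O)[O-])cc1[N+](=O)[O-]` gives 5000 nM. That places compound 1 at the low end of the three numbers, although its gap to compound 2 is within the usual scatter of repeat measurements.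

The next compound to be measured is compound 4 `CCN(CC)/[N+]([O-])=N/Oc1cc(O/N=[N+](\[O-])N(C)C)c([N+](=O)[O-])cc1[N+](=O)[O-]`. It differs from compound 1 in one place: diethylamino in place of 4-(ethoxycarbonyl)piperazin-1-yl on a double-bonded nitrogen.

Three measured steps offer some guidance. Lengthening the ester chain gives a 2.0-fold higher number from compound 1 to compound 2 (0.29 log units; within the scatter). Putting pyrimidin-2-yl in place of ethoxycarbonyl gives a 2.5-fold higher number from compound 1 to compound 3 (0.40 log units; beyond the scatter), and putting it in place of propoxycarbonyl gives a 1.3-fold higher number from compound 2 to compound 3 (0.11 log units; within the scatter). All three steps alter the group on an amine nitrogen in a ring and leave that ring standing. Among the measured compounds shown here, compound 4 loses the ring altogether, so no measured step covers this change directly, and the guidance is only indirect.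

The largest measured step, a 2.5-fold higher number from compound 1 to compound 3 (0.40 log units; beyond the scatter), is still modest. A similarly small step is therefore expected in this assay, most likely towards a higher number and perhaps none beyond the scatter. The estimated step is a 1.5-fold higher number from compound 1 to compound 4 (0.18 log units; within the scatter). For compound 4, the expected value is 3000 nM, with an estimated range from 1100 nM to 8000 nM.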

Compound 4, concentration for total growth inhibition: 2300 nM
Compound 4: middle estimate off by 1.3-fold (0.12 log units), on the high side; measured number inside the range.
By their numbers in this assay, from the lowest: compounds 1, 4, 2 and 3 (each within the scatter of the next, the first and the last beyond it).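

In this assay, diethylamino in place of 4-(ethoxycarbonyl)piperazin-1-yl on this double-bonded nitrogen gives a 1.2-fold higher number from compound 1 to compound 4 (0.06 log units; within the scatter). The earlier steps shown here changed only the group on the ring's amine nitrogen and left the ring standing, whereas this change removes the six-membered ring, the ester and both hydrogen-bond acceptors counted for the departing group, yet the number stays within the scatter of compound 1, so none of these parts is needed at this position to keep growth inhibition at this level. Nothing measured here explains why so large a change in structure leaves the number within the scatter.

The compounds shown leave open how far this freedom extends, for instance whether a pyrrolidin-1-yl or morpholin-4-yl ring, or the longer dipropylamino group, on this nitrogen would also stay within the scatter of compound 1. They also leave open whether the dimethylamino group, which all the compounds shown keep, could be exchanged just as freely, for example for a piperazine with a free amine.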